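Adding a second methyl to compound 2

A few compounds are considered here, and "the series" means these few. Any claim that something is new, unique, unknown or untested is made for them only; others in the source may bear on it.

In an ADME assay on microsomes from liver (Homo sapiens) for metabolic stability, read by LC-MS, using NADPH, with a stated time of 60 min, tested at 1 uM (a higher number here means that the compound lasts longer, a lower number that the compound disappears faster), compound 1 (`COc1ccc(-n2c(N)nc3ccccc32)c(O)c1`) gives 2.07 h and compound 2 (`Cc1ccc(-n2c(N)nc3ccccc32)c(O)c1`) gives 2.7 h, two values within the scatter of each other. Compound 3 (`Nc1nc2ccccc2n1-c1ccccc1O`) is reported only as a limit, > 4.25 h. Compound 2 therefore has one close neighbour on a measured number, and its relation to compound 3 rests on that limit.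

Compound 4 (`Cc1cc(O)c(-n2c(N)nc3ccccc32)cc1C`) keeps the shared core of compound 2 and carries methyl in place of hydrogen on an aromatic carbon. The new methyl stands ortho to a methyl group and para to a hydroxy group.

The nearest measured change runs the other way, with hydrogen in place of methyl giving an at least 1.5-fold higher number from compound 2 to compound 3 (0.19 log units; that floor lies within the scatter). That floor lies within the scatter, so compound 3 gives only weak support for a shorter half-life on adding methyl. Hydrogen in place of methoxy gives an at least 2.0-fold higher number from compound 1 to compound 3 (0.31 log units; beyond the scatter), while methyl in place of methoxy gives only a 1.3-fold higher number from compound 1 to compound 2 (0.12 log units; within the scatter). Within the data shown here, in these three compounds, the one without a substituent at that place holds the limit, although no measured step adds a second group.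

A small fall is expected, probably not clearly beyond the scatter, with an estimated 1.3-fold lower number from compound 2 to compound 4 (0.11 log units; within the scatter). For compound 4, the estimated half-life is 2.1 h, with an expected range of 1.1 h to 3.7 h.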

Compound 4, half-life: 2.15 h
For compound 4 the middle estimate is 1.0-fold (0.01 log units) below the measured one; low and high end bracket the measured number.
By their numbers in this assay, from the lowest: compounds 1, 4 and 2 (each within the scatter of the next). At a limit, above all of these: compound 3.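

In this assay, methyl in place of hydrogen on an aromatic carbon, ortho to a methyl group and para to a hydroxy group, gives a 1.3-fold lower number from compound 2 to compound 4 (0.10 log units; within the scatter). Among these compounds, the earlier steps only exchanged one group at a single place, so this is the first reading of a second group added to the ring, and here a second methyl leaves the half-life of compound 4 indistinguishable from that of compound 2. The weak hint from the earlier steps, that a substituent costs half-life, therefore finds no confirmation at this position, since the step stays within the scatter and a small loss can be neither shown nor excluded.

The distance from these compounds to compound 3 has no measured size, since compound 3 is reported only as a limit: the limit of > 4.25 h in this assay, at which 1 of the 4 values shown sits. Going by these compounds, whether this place tolerates anything other than methyl also stays open, for example an amine, a carboxylic acid or a longer chain, and so does whether a methoxy group there would read the same as methyl.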